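Thiophene replacement for a triheteroatom ring in a sulfoxide series

This account rests on a few compounds, and the source may have more. Where it says the series, first, only, none or still open, it means among the compounds named here.

For the measured compounds named here, compound 2 `O=c1[nH]nc(C[S+]([O-])C(c2ccccc2)c2ccccc2)s1` gives 38100 nM in an assay on HEK293 cells for inhibition of sodium-dependent dopamine transporter (Homo sapiens), read by scintillation counting, with stated times of 5 min and 1 min (a lower number here means a stronger inhibitor, a higher number a weaker inhibitor), and stands as the higher of the two numbers measured so far. Compound 1 `[O-][S+](Cc1ccc(Cl)s1)C(c1ccccc1)c1ccccc1` gives 12800 nM in this assay. Compound 3 `[O-][S+](Cc1ccsc1)C(c1ccccc1)c1ccccc1` is not yet measured; it differs from compound 2 by a group of 5 heavy atoms (4 carbon, 1 sulfur; one five-membered aromatic ring with 1 hetero atom) in place of a group of 6 heavy atoms (2 carbon, 2 nitrogen, 1 oxygen, 1 sulfur; one five-membered aromatic ring with 3 hetero atoms), on a saturated chain carbon bound to a sulfur. Going by the values given here, the one measured step that bears on this exchange, a 3.0-fold higher number from compound 1 to compound 2 (0.47 log units; beyond the scatter), ran in the opposite sense, with a ring of one hetero atom replaced by one of three. Compound 3 is therefore expected to show a 2.5-fold lower number from compound 2 to compound 3 (0.40 log units; beyond the scatter), a modest lowering, with an estimate of 15000 nM and a range from 6000 nM to 40000 nM.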

Compound 3, half-maximal inhibitory concentration: 3000 nM
Estimate against measurement, compound 3: 5.0-fold (0.70 log units) above, outside the stated range (below it).
By their numbers in this assay, from the lowest: compound 3; then compound 1; then compound 2.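

In this assay the ring exchange on a saturated chain carbon bound to a sulfur spans more than the earlier step showed: a 13-fold lower number from compound 2 to compound 3 (1.10 log units; beyond the scatter) is a large step, and compound 3 has the lowest number of the series. Rings with the same hetero atom count also differ: a 4.3-fold lower number from compound 1 to compound 3 (0.63 log units; beyond the scatter) comes with thiophen-3-yl in place of 5-chlorothiophen-2-yl, so that count alone does not set the number. No measurement shown here explains either step.

The chlorine and the ring attachment change together between compound 1 and compound 3, and the compounds shown do not separate them. On these data alone, how an amine or a carboxylic acid at this place would read remains open.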